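This account rests on a few compounds, and the source may have more. Where it says the series, first, only, none or still open, it means among the compounds named here.

Measured so far in an ADME assay on the whole organism (plasma, strain 129/SvEvBrd x C57BL/6) for pharmacokinetics, with Mus musculus as the target, at a dose of 10 mg/kg by the oral route (a lower number here means less compound in the circulation, a higher number more compound in the circulation at the dose given), are these compounds:
Compound 1 `CC(=O)c1cccc([C@@H](O)[C@H](O)[C@H](O)CO)n1` with 10500 ng.h/mL
Compound 2 `CC(=O)c1ncc([C@@H](O)[C@H](O)[C@H](O)CO)s1` with 668 ng.h/mL
Compound 3 `CC(O)c1nc([C@@H](O)[C@H](O)[C@H](O)CO)c[nH]1` with 10300 ng.h/mL

Compound 3 stands level with compound 1 within the scatter, while compound 2 lies beyond the scatter on the lower side. Compound 4 `CN(C)C(=O)c1nc([C@@H](O)[C@H](O)[C@H](O)CO)c[nH]1` has not yet been measured. It carries dimethylcarbamoyl in place of 1-hydroxyethyl on an aromatic carbon and otherwise matches compound 3. Among the measured compounds shown here, no measured pair isolates this change, so the expectation rests only on the spread of the three values. In this assay a modest fall is expected, probably just beyond the scatter. The estimated change is a 2.6-fold lower number from compound 3 to compound 4 (0.41 log units; beyond the scatter) in this measure. For compound 4 the estimate is 4000 ng.h/mL with an expected range from 900 ng.h/mL to 15000 ng.h/mL at this dose.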

Compound 4, area under the concentration-time curve: 1740 ng.h/mL
The estimate for compound 4 lay 2.3-fold (0.36 log units) above the measured number, and the stated range covers the measured number.
By their numbers in this assay, from the lowest: compound 2; then compound 4; then compounds 3 and 1 (each within the scatter of the next).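

In this assay, among the compounds shown here, this is the first step that changes one place alone, and it shows that the aromatic carbon between two ring nitrogen atoms is sensitive to its group: dimethylcarbamoyl in place of 1-hydroxyethyl gives a 5.9-fold lower number from compound 3 to compound 4 (0.77 log units; beyond the scatter), a modest loss. Nothing measured here explains the fall. As far as these compounds go, whether it follows from the larger group or from the loss of the hydroxyl stays open. A primary carboxamide, a methylamino carbonyl group or a carboxylic acid at this carbon could separate these readings.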